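Extending the side chain of compound 1

This account rests on a few compounds, and the source may have more. Where it says the series, first, only, none or still open, it means among the compounds named here.

Measured in a functional assay on K562 cells (Homo sapiens) for inhibition, read by fluorescence, with a stated time of 72 h; on this read-out higher numbers stand for weaker inhibition of growth and lower numbers for stronger inhibition of growth:

compound 1 `CC(C)=CCn1cnc2c(Nc3cccc(Cl)c3)nc(N[C@H]3CC[C@H](N)CC3)nc21` gives 3500 nM
compound 2 `CCCCCCn1cnc2c(Nc3cc(OC)cc(OC)c3)nc(N[C@H]3CC[C@H](N)CC3)nc21` gives 1900 nM
compound 3 `CC(C)CCn1cnc2c(Nc3ccccc3)nc(N[C@H]3CC[C@H](N)CC3)nc21` gives 3500 nM

Compound 1 stands level with compound 3, and compound 2 lies within the scatter of both, so these three values cannot be ranked. Compound 4 `CC(C)=CCC/C(C)=C/Cn1cnc2c(Nc3cccc(Cl)c3)nc(N[C@H]3CC[C@H](N)CC3)nc21` comes from compound 1 through a single change: 3-methylbut-2-en-1-yl in place of hydrogen on a saturated chain carbon bound to a double-bonded chain carbon. In words, 3-methylbut-2-en-1-yl takes the place of hydrogen on a saturated chain carbon bound to a double-bonded chain carbon, turning 3-methylbut-2-en-1-yl into 3,7-dimethylocta-2,6-dien-1-yl.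

For the measured compounds named here, no two measured compounds differ in this chain alone, so the data offer no direct guide. The chains seen so far differ, yet compound 3 gives 3500 nM and compound 2 gives 1900 nM, which is within the scatter. Only a small step is therefore expected in this assay, towards a lower number if there is one, and perhaps none beyond the scatter. The expected change is a 1.8-fold lower number from compound 1 to compound 4 (0.24 log units; within the scatter). For compound 4 the estimate is 2000 nM, with an expected range of 700 nM to 6000 nM.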

Compound 4, concentration for 50% growth inhibition: 2200 nM
Compound 4: the middle estimate sits 1.1-fold (0.04 log units) below what was measured; the range from low to high includes it.
By their numbers in this assay, from the lowest: compounds 2, 4, 1 and 3 (each within the scatter of the next).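

For the compounds shown here, compound 1 and compound 4 differ only in the chain, so this pair gives the first direct reading at this position, which the earlier compounds could not provide. Replacing hydrogen on a saturated chain carbon bound to a double-bonded chain carbon turns 3-methylbut-2-en-1-yl into 3,7-dimethylocta-2,6-dien-1-yl, and in this assay this gives a 1.6-fold lower number from compound 1 to compound 4 (0.20 log units; within the scatter), so the much larger chain brings no clear gain or loss in growth inhibition. No measured evidence here explains this outcome.

As far as these compounds go, it remains open whether a much shorter group such as methyl, or a chain ending in an amine or a carboxylic acid, would also leave the read-out within the scatter. From the compounds shown here alone, it is also open whether the same chain exchange would give a similar result alongside the other groups carried by compound 2 and compound 3.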